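This account rests on a few compounds, and the source may have more. Where it says the series, first, only, none or still open, it means among the compounds named here.

Among the measured compounds shown here, compound 2 `COc1ccc(S(=O)(=O)N2CCc3cccc(-c4ccc(F)nc4)c32)cc1` gives 145 nM in a functional assay on MKN-45 cells (Homo sapiens) for inhibition, with a stated time of 72 h (a lower number here means a stronger inhibitor, a higher number a weaker inhibitor), and stands second highest of the three numbers so far; compound 1 `COc1ccc(S(=O)(=O)N2CCc3cccc(-c4ccc(N)cc4)c32)cc1` gives 162 nM in this assay, and compound 3 `COc1ccc(S(=O)(=O)N2CCc3cccc(-c4ccc(F)cc4)c32)cc1` gives 79 nM. Compound 4 `COc1ccc(S(=O)(=O)N2CCc3cccc(-c4cccc(F)c4)c32)cc1` has not been measured in this assay; relative to compound 2 the change is 3-fluorophenyl in place of 6-fluoropyridin-3-yl on an aromatic carbon. The step that bears on this is the one where the same 6-fluoropyridin-3-yl left and 4-fluorophenyl entered, a 1.8-fold lower number from compound 2 to compound 3 (0.26 log units; within the scatter), which stayed within the scatter. The step of a 1.1-fold lower number from compound 1 to compound 2 (0.05 log units; within the scatter) also stayed within the scatter. A step of similar size, downward or none beyond the scatter, is therefore expected: a 1.3-fold lower number from compound 2 to compound 4 (0.12 log units; within the scatter). Compound 4 is estimated at 110 nM, with a range from 55 nM to 220 nM.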

Compound 4, half-maximal inhibitory concentration: 84.7 nM
Beside the measured number, compound 4's estimate is 1.3-fold (0.11 log units) above it, and the stated range covers the measured number.
By their numbers in this assay, from the lowest: compounds 3, 4, 2 and 1 (each within the scatter of the next, the first and the last beyond it).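

In this assay, 3-fluorophenyl and 4-fluorophenyl read alike on this aromatic carbon (a 1.1-fold higher number from compound 3 to compound 4 (0.03 log units; within the scatter)), so shifting the fluoro around the phenyl does not separate these two compounds. The swap from 6-fluoropyridin-3-yl (a 1.7-fold lower number from compound 2 to compound 4 (0.23 log units; within the scatter)) and the swap from 4-aminophenyl (a 1.9-fold lower number from compound 1 to compound 4 (0.28 log units; within the scatter)) also stay within the scatter, leaving compound 4 unresolved from all three earlier compounds. No supporting data on hand account for these readings.

Open, on these data alone, is whether a larger change here, such as a carboxylic acid or a morpholine on the phenyl in place of the fluoro, would move the number beyond the scatter.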